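The source may hold more compounds than are shown below. What is called first, only, known or untested is meant among the compounds shown, and "the series" means these compounds.

Measured compounds in the series:

compound 1 `CCCn1c(=N)sc2cc(OC(F)(F)F)ccc21`: 4.5 mg/kg
compound 2 `CCN(CC)C(=O)Cn1c(=N)sc2cc(OC(F)(F)F)ccc21`: 9 mg/kg
compound 3 `CCSCCn1c(=N)sc2cc(OC(F)(F)F)ccc21`: 2.2 mg/kg

All three share one core and differ only in the chain on the aromatic nitrogen. In a functional assay on the whole organism with Rattus norvegicus as the target (a higher number here means that more compound is needed for the effect, a lower number that less compound is needed), compound 3 gives the lowest number of the three, with compound 1 nearest and compound 2 furthest; the step of a 2.0-fold lower number from compound 1 to compound 3 (0.31 log units; beyond the scatter) and the step of a 4.1-fold lower number from compound 2 to compound 3 (0.61 log units; beyond the scatter) both exceed the scatter, while the step of a 2.0-fold higher number from compound 1 to compound 2 (0.30 log units; within the scatter) does not.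

Compound 4 `CNCCn1c(=N)sc2cc(OC(F)(F)F)ccc21` has not been measured. Relative to compound 3 the change is methylamino in place of ethylsulfanyl on a saturated chain carbon, two bonds along the chain from an aromatic nitrogen. Within the data shown here, no measured step replaces ethylsulfanyl with methylamino, so the only guidance is indirect: the step of a 2.0-fold lower number from compound 1 to compound 3 (0.31 log units; beyond the scatter) shows that adding ethylsulfanyl to the chain lowered the number modestly, and the step of a 4.1-fold lower number from compound 2 to compound 3 (0.61 log units; beyond the scatter) shows the chain bearing a diethylcarbamoyl gave a higher number than the chain bearing ethylsulfanyl. Removing ethylsulfanyl is therefore expected to give back part of that gain, so compound 4 is expected to land near compound 1, with the estimated step of a 2.0-fold higher number from compound 3 to compound 4 (0.31 log units; beyond the scatter) in this assay. The estimate for compound 4 is 4.5 mg/kg, with a range from 1.5 mg/kg to 14 mg/kg.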

Compound 4, dose for half-maximal effect: > 10 mg/kg
Compound 4 was reported as a limit; the forecaster's own chance of this, stated with the estimate: 5%; middle value at least 2.2-fold (0.34 log units) away from the limit.
By their numbers in this assay, from the lowest: compound 3; then compounds 1 and 2 (each within the scatter of the next). At a limit, above all of these: compound 4.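

In this assay compound 4 is reported only as a limit: the limit of > 10 mg/kg in this assay, at which 1 of the 4 values shown sits.

Among these compounds, at this place on the chain, methylamino in place of ethylsulfanyl gives an at least 4.5-fold higher number from compound 3 to compound 4 (0.65 log units; beyond the scatter), and the same group also gives an at least 2.2-fold higher number from compound 1 to compound 4 (0.34 log units; beyond the scatter), so the end of the chain can move the number upward as well as downward, which the earlier steps to compound 3 did not show. Against the diethylcarbamoyl chain the reading is weaker, with an at least 1.1-fold higher number from compound 2 to compound 4 (0.04 log units; that floor lies within the scatter), so no order can be given for that pair.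

The compounds shown leave open whether the shift goes with the nitrogen itself or with its hydrogen-bond donor; a dimethylamino or a methoxy group at the same place would separate the two. From the compounds shown here alone, how far compound 4 lies past its limit also stays unknown.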